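This account rests on a few compounds, and the source may have more. Where it says the series, first, only, none or still open, it means among the compounds named here.

Measured so far:
Compound 1 `O=C(NCc1ccc(S(=O)(=O)c2ccccc2)cc1)NCc1cccnc1` gives 19 nM in an assay on isolated protein for inhibition of Nicotinamide phosphoribosyltransferase (Homo sapiens), read by mass spectrometry, with stated times of 15 min and 30 min; on this read-out lower numbers stand for stronger inhibition and higher numbers for weaker inhibition.
Compound 2 `O=C(NCc1ccc(S(=O)(=O)c2cccc(C(F)(F)F)c2)cc1)N1Cc2ccncc2C1` gives 8 nM in this assay.

Compound 2 has the lower of the two numbers, with compound 1 giving a higher one beyond the usual scatter. Compound 3 `O=C(NCc1ccc(S(=O)(=O)c2cc(F)cc(F)c2)cc1)N1Cc2ccncc2C1` differs from compound 2 in one place: 3,5-difluorophenyl in place of 3-(trifluoromethyl)phenyl on a sulfonyl sulfur. Among the compounds with values here, no measured pair shows this kind of change, so there is no step to lean on. The expectation is that the step of a 1.3-fold higher number from compound 2 to compound 3 (0.10 log units; within the scatter) stays within the scatter, in neither direction. Compound 3 is therefore estimated at 10 nM, in a range from 4 nM to 25 nM.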

Compound 3, half-maximal inhibitory concentration: 7.1 nM
The estimate for compound 3 lay 1.4-fold (0.15 log units) above the measured number; measured number inside the range.
By their numbers in this assay, from the lowest: compounds 3 and 2 (each within the scatter of the next); then compound 1.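

Putting 3,5-difluorophenyl in place of 3-(trifluoromethyl)phenyl on the sulfonyl sulfur gives a 1.1-fold lower number from compound 2 to compound 3 (0.05 log units; within the scatter) in this assay. Within the data shown here, this is the first pair to differ only at this place, and on this read-out the two groups cannot be told apart. Nothing available explains this match. Still open, going by these compounds, is whether this place accepts groups of a different kind, such as an amine or a carboxylic acid on the ring. The compounds shown also leave open whether a change elsewhere in the shared core would behave the same way.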